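From 4-methoxyphenyl to 4-methylphenyl: one small exchange

The compounds below may be only part of what the source reports. "The series", "measured", "known", "first", "only" and "open" are said of these compounds alone.

Of the compounds shown here, three built on a shared core have been measured in a functional assay on A549 cells (Homo sapiens) for inhibition, read by CCK-8 assay, with a stated time of 72 h, tested at 1 uM; on this read-out higher numbers stand for more inhibition of growth at the one concentration tested and lower numbers for less inhibition of growth. Compound 1 (`CN(C)C(=O)c1cc2cnc(Nc3ccc(NC(=O)C4(C(=O)Nc5ccc(Cl)cc5)CC4)cc3)nc2n1C1CCCC1`) gives 24.7%, compound 2 (`CN(C)C(=O)c1cc2cnc(Nc3ccc(NC(=O)C4(C(=O)Nc5cccc(F)c5)CC4)cc3)nc2n1C1CCCC1`) gives 33.2%, and compound 3 (`COc1ccc(NC(=O)C2(C(=O)Nc3ccc(Nc4ncc5cc(C(=O)N(C)C)n(C6CCCC6)c5n4)cc3)CC2)cc1`) gives 74.4%. Compound 3 stands highest of the three, and its lead over each of the others is beyond the scatter. The other two stay close, with a number 8.5 percentage points higher from compound 1 to compound 2 (within the scatter).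

Compound 4 (`Cc1ccc(NC(=O)C2(C(=O)Nc3ccc(Nc4ncc5cc(C(=O)N(C)C)n(C6CCCC6)c5n4)cc3)CC2)cc1`) carries methyl in place of methoxy on an aromatic carbon, para to a large group: methyl in place of methoxy on an aromatic carbon. Among the measured compounds shown here, no measured step makes this exact exchange. The nearest evidence is the replacement of chloro by methoxy, a number 49.7 percentage points higher from compound 1 to compound 3 (beyond the scatter), and of 3-fluorophenyl by 4-methoxyphenyl, a number 41.2 percentage points higher from compound 2 to compound 3 (beyond the scatter). Both are large, so a change at this ring alone can move the number in this assay a long way. Only compound 3 carries methoxy, and the data cannot show how methyl will compare. A downward step of moderate size is therefore expected, falling short of those two gaps. The expected change is a number 19.4 percentage points lower from compound 3 to compound 4 (beyond the scatter). For compound 4 the estimated value is 55%, within an expected range of 30% to 80%.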

Compound 4, percent growth inhibition at one concentration: 40.2%
Compound 4: middle estimate off by 14.8 percentage points, on the high side; the range from low to high includes it.
By their numbers in this assay, from the lowest: compounds 1, 2 and 4 (each within the scatter of the next, the first and the last beyond it); then compound 3.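

In this assay, the step of a number 34.2 percentage points lower from compound 3 to compound 4 (beyond the scatter) shows that a large change in the number can come from the exchange of methoxy for methyl alone, on an aromatic carbon para to a large group. Earlier, the gains of compound 3 were set against compounds with a chloro or a 3-fluorophenyl group, so they could not say whether methoxy mattered or whether those groups merely held the number down; now, with methyl in place of chloro, the rise is only modest, a number 15.5 percentage points higher from compound 1 to compound 4 (beyond the scatter), and the step of a number 7 percentage points higher from compound 2 to compound 4 (within the scatter) lies within the scatter, which leaves compound 3 alone among these four, with compound 4 not set apart from compound 2. Nothing given here explains why methoxy stands apart from methyl at this place.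

The compounds shown leave open whether an ethoxy group, a hydroxy group or a dimethylamino group at the same place would keep the number of compound 3 or fall back towards that of compound 4. They also leave open whether methoxy would count for as much elsewhere on this ring.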